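The source may hold more compounds than are shown below. What is called first, only, known or untested is meant among the compounds shown, and "the series" means these compounds.

Compound 1 `FC(F)(F)c1ccc(CSc2nc(Nc3ccccc3)c3ccccc3n2)cc1` carries an unsubstituted phenyl on the nitrogen of the shared core, and in a functional assay on MDA-MB-231 cells (Homo sapiens) for cytotoxicity, read by MTT assay, with a stated time of 72 h (a higher number here means a weaker inhibitor, a lower number a stronger inhibitor), compound 1 gives 18400 nM. Compound 2 `O=[N+]([O-])c1cccc(Nc2nc(SCc3ccc(C(F)(F)F)cc3)nc3ccccc23)c1` differs from it only by a nitro in place of hydrogen on an aromatic carbon, and in this assay compound 2 gives 31500 nM. Among the measured compounds shown here, that single change is a 1.7-fold higher number from compound 1 to compound 2 (0.23 log units; within the scatter), so the two measured numbers sit together, and compound 2 has compound 1 as its only neighbour among a pair that cannot be told apart. Compound 3 `COc1ccc(Nc2nc(SCc3ccc(C(F)(F)F)cc3)nc3ccccc23)cc1` is the next step out from compound 2: 4-methoxyphenyl in place of 3-nitrophenyl on a nitrogen on an aromatic ring. For the measured compounds named here, no measured step involves a methoxy group, and the only measured step on that nitrogen, a 1.7-fold higher number from compound 1 to compound 2 (0.23 log units; within the scatter), shows that changing the substitution on this ring left the number essentially where it was. The expectation for compound 3 is therefore a step of a 1.4-fold lower number from compound 2 to compound 3 (0.16 log units; within the scatter), nothing beyond the scatter. The estimate for compound 3 in this assay is 22000 nM, with a range from 7000 nM to 70000 nM.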

Compound 3, half-maximal inhibitory concentration: 15700 nM
For compound 3 the middle estimate is 1.4-fold (0.15 log units) above the measured one; low and high end bracket the measured number.
By their numbers in this assay, from the lowest: compounds 3, 1 and 2 (each within the scatter of the next).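

Among the compounds shown here, compound 3 brings the first measured methoxy group on this ring. In this assay, going from the unsubstituted phenyl to 4-methoxyphenyl gives a 1.2-fold lower number from compound 1 to compound 3 (0.07 log units; within the scatter), and the direct exchange of 3-nitrophenyl for 4-methoxyphenyl on this nitrogen gives a 2.0-fold lower number from compound 2 to compound 3 (0.30 log units; within the scatter), so the unsubstituted phenyl, 3-nitrophenyl and 4-methoxyphenyl cannot be told apart in this assay, even though the last two carry different groups at different places on the ring. No available evidence speaks to why these three compounds read alike.

The compounds shown leave open whether any group on this ring would separate from the scatter, for instance an amine or a carboxylic acid, or whether a longer chain in place of the ring would do so. They also leave open how a 4-nitrophenyl or a 3-methoxyphenyl would read, and what would follow from replacing the trifluoromethyl group, which all three compounds share.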